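Solubility in a quinoline series: replacing an aryl substituent

A few compounds are considered here, and "the series" means these few. Any claim that something is new, unique, unknown or untested is made for them only; others in the source may bear on it.

The series shares one core, carried by compound 1 `COc1ccc(-c2ccc3c(NCCCNCc4cccc(OC)c4O)ccnc3c2)cc1`, compound 2 `CC(C)Cc1ccc2c(NCCCNCc3ccco3)ccnc2c1` and compound 3 `COc1ccc(-c2ccc3c(NCCCNCc4ccco4)ccnc3c2)cc1`. In a physicochemical assay for solubility, with a stated time of 18 h, at pH 7.4 (a lower number here means a less soluble compound, a higher number a more soluble compound), compound 1 gives 32000 nM, compound 3 gives 32000 nM and compound 2 gives 4200 nM. Compound 1 therefore stands level with compound 3 at the digits shown, the two together the highest of the three numbers, and furthest from compound 2, as no change at the digits printed from compound 1 to compound 3 (within the scatter) and a 7.6-fold higher number from compound 2 to compound 3 (0.88 log units; beyond the scatter) record.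

Compound 4 `COc1cccc(CNCCCNc2ccnc3cc(Cc4ccc(F)cc4Cl)ccc23)c1O` is not yet measured. Its change from compound 1 is 2-chloro-4-fluorobenzyl in place of 4-methoxyphenyl on an aromatic carbon. Going by the values given here, of the measured steps, no change at the digits printed from compound 1 to compound 3 (within the scatter) concerns the other end of the molecule and bears little on it; the only step at the same aromatic carbon is a 7.6-fold higher number from compound 2 to compound 3 (0.88 log units; beyond the scatter), a modest shift when one substituent replaced another there. A step of that order, in either direction, is therefore the expected range for compound 4, with a somewhat lower number expected on balance: a 2.7-fold lower number from compound 1 to compound 4 (0.43 log units; beyond the scatter). The estimate for compound 4 in this assay is 12000 nM, within 3000 nM to 40000 nM.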

Compound 4, solubility: 4200 nM
Compound 4: middle estimate off by 2.9-fold (0.46 log units), on the high side; low and high end bracket the measured number.
By their numbers in this assay, from the lowest: compounds 2 and 4 (each within the scatter of the next); then compounds 1 and 3 (each within the scatter of the next).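

In this assay, the second substitution at this aromatic carbon gives a 7.6-fold lower number from compound 1 to compound 4 (0.88 log units; beyond the scatter), which matches in size a 7.6-fold higher number from compound 2 to compound 3 (0.88 log units; beyond the scatter), although the two pairs carry different groups at the other end of the molecule, 2-hydroxy-3-methoxyphenyl in one and furan-2-yl in the other. Across these two pairs, the compound bearing 4-methoxyphenyl has the higher number, and neither pair goes against this, so the position has now shown the same step size with two different replacements for that group. No supporting data bear on the cause of this step.

The compounds shown leave open whether 2-chloro-4-fluorobenzyl would give a similar step alongside furan-2-yl at the other end. As far as these compounds go, how an unsubstituted benzyl, a morpholine or a carboxylic acid would read at this aromatic carbon also remains open.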